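The compounds below may be only part of what the source reports. "The series", "measured", "known", "first", "only" and "open" are said of these compounds alone.

Measured in an ADME assay on HepG2 cells (Homo sapiens) for cytotoxicity, in the presence of a further agent that is not named here; on this read-out lower numbers stand for stronger inhibition and higher numbers for weaker inhibition:
Compound 1 `CN(Cc1ccccc1)C(=O)c1nc(Cc2ccccc2C(F)(F)F)n(C)c(=O)c1O`: > 100000 nM (a limit)
Compound 2 `Cn1c(Cc2ccccc2)nc(C(=O)NCc2ccccc2)c(O)c1=O`: > 100000 nM (a limit)
Compound 3 `Cc1nc(C(=O)NCc2ccccc2)c(O)c(=O)n1C`: > 100000 nM (a limit)

Compound 1 has no number in this assay, only a limit. The same holds across the whole set, which is summed up as the limit of > 100000 nM in this assay, at which 3 of the 3 values shown sit.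

Compound 4 `Cn1c(Cc2ccccc2C(F)(F)F)nc(C(=O)NCc2ccccn2)c(O)c1=O` has not yet been measured. It differs from compound 1 by ((pyridin-2-yl)methyl)amino in place of benzyl(methyl)amino on a carbonyl carbon.

Among the measured compounds shown here, only one measured step is available, a step that the two limits leave unreadable from compound 2 to compound 3, and its size cannot be read. That step is also a change at a saturated chain carbon, not on the carbonyl carbon, so it bears on the present change only weakly. For the measured compounds named here, no measured step covers the change at the carbonyl carbon.

With no size to carry over, no step beyond the scatter is expected in this assay, in either direction. Compound 4 is expected to end up as a limit too, because of the limit of > 100000 nM in this assay, at which 3 of the 3 values shown sit.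

The step expected on this reasoning is a step that the limit leaves unreadable from compound 1 to compound 4. For compound 4 the estimated value is 120000 nM, with an expected range from 50000 nM to 300000 nM.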

Compound 4, half-maximal inhibitory concentration: > 100000 nM
Compound 4: no number, only a limit; the forecaster's own chance of this, stated with the estimate: 85%; the middle value does not contradict the limit.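

In this assay compound 4 gives > 100000 nM, which is a limit and not a number. Compound 1 also has only a limit, and no step can be read from compound 1 to compound 4. The set stays at one value: the limit of > 100000 nM in this assay, at which 4 of the 4 values shown sit. The compounds shown leave open where their true values lie, and whether the change at the carbonyl carbon has any effect.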